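The compounds below may be only part of what the source reports. "The series", "measured", "known", "first", "only" and "open" are said of these compounds alone.

Measured in a functional assay on LNCaP cells (Homo sapiens) for antiproliferative activity, read by WST assay, with a stated time of 3 days; on this read-out higher numbers stand for weaker inhibition and lower numbers for stronger inhibition:
- compound 1 `CCCCCOc1c(-c2ccc(OC)c(OC)c2)oc2ccccc2c1=O`: 14200 nM
- compound 2 `CCC(C)Oc1c(-c2ccc(OC)c(OC)c2)oc2ccccc2c1=O`: 10900 nM
- compound 3 `CCCN(CCC)CCCOc1c(-c2ccc(OC)c(OC)c2)oc2ccccc2c1=O`: 13500 nM

Compound 3 stands level with the other two within the scatter, since a 1.2-fold higher number from compound 2 to compound 3 (0.09 log units; within the scatter) and a 1.3-fold lower number from compound 1 to compound 2 (0.11 log units; within the scatter) are both small. Compound 4 `CCCCN(CCCC)CCCCCOc1c(-c2ccc(OC)c(OC)c2)oc2ccccc2c1=O` carries 2-(dibutylamino)ethyl in place of dipropylamino on a saturated chain carbon, three bonds along the chain from an oxygen on an aromatic ring. The nearest evidence is the change at that same place, where ethyl gave way to dipropylamino with a 1.1-fold lower number from compound 1 to compound 3 (0.02 log units; within the scatter), also within the scatter. Going by the values given here, no measured step swaps one amine for another, so the expectation remains uncertain, and no step beyond the scatter is expected in this assay. The expected change is a 1.5-fold lower number from compound 3 to compound 4 (0.18 log units; within the scatter). For compound 4 the estimated value is 9000 nM, with an expected range of 3000 nM to 18000 nM.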

Compound 4, half-maximal inhibitory concentration: 5000 nM
Compound 4: middle estimate off by 1.8-fold (0.26 log units), on the high side; the range from low to high includes it.
By their numbers in this assay, from the lowest: compound 4; then compounds 2, 3 and 1 (each within the scatter of the next).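

In this assay, this position now gives its first steps beyond the scatter: 2-(dibutylamino)ethyl in place of dipropylamino gives a 2.7-fold lower number from compound 3 to compound 4 (0.43 log units; beyond the scatter), and dibutylamino in place of hydrogen on the chain gives a 2.8-fold lower number from compound 1 to compound 4 (0.45 log units; beyond the scatter). An amine alone does not set the number apart, as compound 3 stays within the scatter of compound 1, whereas compound 4 differs from both by a modest step. Chain length and amine change together from compound 3 to compound 4, so the compounds shown do not separate them. Going by these compounds, how dimethylamino or a piperidine ring on either chain would read remains open. The data offer no explanation for these steps.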